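This account rests on a few compounds, and the source may have more. Where it says the series, first, only, none or still open, it means among the compounds named here.

Three related compounds have so far been examined in a functional assay on the whole organism (Tail, strain ICR) with Mus musculus as the target, in the tail flick test, with a stated time of 30 min, at a dose of 25 umol/kg by the oral route; on this read-out lower numbers stand for a weaker effect and higher numbers for a stronger effect at the one dose given. Compound 1, with the structure `O=C(CN(c1nc(Cl)nc2[nH]cnc12)C1CC1)NCC(=O)OCc1ccccc1`, gives 18.7% in this assay. Compound 2, with the structure `O=C(CN(c1ncnc2c1ncn2C1CCCCO1)C1CC1)N[C@@H](CCC(=O)OCc1ccccc1)C(=O)OCc1ccccc1`, gives 32.6% in this assay, and compound 3, with the structure `CC[C@H](C)[C@H](NC(=O)CN(c1nc(Cl)nc2[nH]cnc12)C1CC1)C(=O)O`, gives 30.3% in this assay. On these numbers compound 1 stands lowest of the three: the nearest, compound 3, lies above it by a gap beyond the scatter, and the furthest, compound 2, lies above it by a somewhat larger gap, also beyond the scatter.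

Compound 4, with the structure `O=C(CN(c1nc(Cl)nc2[nH]cnc12)C1CC1)N[C@@H](CC(=O)OCc1ccccc1)C(=O)OCc1ccccc1`, has not yet been measured. It differs from compound 1 in one place: (benzyloxycarbonyl)methyl in place of hydrogen on a saturated chain carbon bound to an amide-type nitrogen and a carbonyl carbon. For the measured compounds named here, no pair of measured compounds differs in a single place, so no measured step guides this change directly. Both compound 2 and compound 3 carry a group in that same kind of place and give higher numbers than compound 1, so a modest rise is expected, with the step from compound 1 to compound 4 estimated at a number 9.3 percentage points higher from compound 1 to compound 4 (within the scatter). Compound 4 is expected to give about 28% in this assay, within a range from 14% to 42%.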

Compound 4, a percentage reported as activity, at one dose (the size of the read-out at that dose, not a potency): 34.7%
Beside the measured number, compound 4's estimate is 6.7 percentage points below it; the range from low to high includes it.
By their numbers in this assay, from the lowest: compound 1; then compounds 3, 2 and 4 (each within the scatter of the next).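

In this assay, for the compounds shown here, putting (benzyloxycarbonyl)methyl in place of hydrogen on a saturated chain carbon bound to an amide-type nitrogen and a carbonyl carbon gives a number 16 percentage points higher from compound 1 to compound 4 (beyond the scatter), the first step at this position that can be read as one single change. It shows that this carbon can carry a group of this size without the effect at the one dose given being lost, and that here the effect is larger with the group than with hydrogen. No measurement shown explains this rise.

The compounds shown leave open which part of the new group matters, since no single-place step tests a plain methyl, a longer chain, or a carboxylic acid in place of the benzyl ester at this carbon. From the compounds shown here alone, whether the step holds at other doses also remains open.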